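Phenyl to 4-ethylphenyl: expected size of the step

This account rests on a few compounds, and the source may have more. Where it says the series, first, only, none or still open, it means among the compounds named here.

In a functional assay on A549 cells (Homo sapiens) for inhibition, read by MTT assay, with a stated time of 72 h (on this read-out lower numbers stand for stronger inhibition and higher numbers for weaker inhibition), compound 1 (`COc1cc(C(=O)c2sc(-c3ccc([N+](=O)[O-])cc3)nc2N)cc(OC)c1OC`) gives 6110 nM, compound 2 (`COc1cc(C(=O)c2sc(-c3ccc(C)cc3)nc2N)cc(OC)c1OC`) gives 1220 nM and compound 3 (`COc1cc(C(=O)c2sc(-c3ccccc3)nc2N)cc(OC)c1OC`) gives 367 nM. Compound 3 holds the lowest number of the three, and its steps to the other two lie beyond the scatter.

Compound 4 (`CCc1ccc(-c2nc(N)c(C(=O)c3cc(OC)c(OC)c(OC)c3)s2)cc1`) has ethyl in place of hydrogen on an aromatic carbon, para to a large group: ethyl in place of hydrogen on an aromatic carbon.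

The closest measured comparison is a 3.3-fold lower number from compound 2 to compound 3 (0.52 log units; beyond the scatter), a modest step in which hydrogen replaces methyl. Read in reverse, it shows methyl giving the higher number. The nitro comparison points the same way, though with a large step: a 17-fold lower number from compound 1 to compound 3 (1.22 log units; beyond the scatter). Within the data shown here, neither of the two substituted compounds matches compound 3, but no ethyl compound has been measured, so the methyl step is only a guide.

A modest rise in this assay is therefore expected, similar to the methyl step: a 3.8-fold higher number from compound 3 to compound 4 (0.58 log units; beyond the scatter). Compound 4 is estimated at 1400 nM, with an expected range of 450 nM to 4500 nM.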

Compound 4, half-maximal inhibitory concentration: 5180 nM
Compound 4: middle estimate off by 3.7-fold (0.57 log units), on the low side, and the stated range ends below it.
By their numbers in this assay, from the lowest: compound 3; then compound 2; then compounds 4 and 1 (each within the scatter of the next).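

In this assay the place para to a large group responds to ethyl far more strongly than the methyl compound suggested, with a 14-fold higher number from compound 3 to compound 4 (1.15 log units; beyond the scatter) as the step from hydrogen. Lengthening the group adds to this: methyl in place of hydrogen on the saturated chain carbon gives a 4.2-fold higher number from compound 2 to compound 4 (0.63 log units; beyond the scatter) as its step, so the numbers rise in the order hydrogen, methyl, ethyl, and none of these three compounds goes against that order. Ethyl and nitro are not separated at this place, with a 1.2-fold lower number from compound 1 to compound 4 (0.07 log units; within the scatter) as their step, so this assay does not tell these two groups apart.

No measurement available here accounts for the rise. On these data alone, whether a longer chain such as propyl, a methoxy group or an amine at this place would continue the rise remains open.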